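Amino in Place of Methyl: Compound 3 to Compound 4

A few compounds are considered here, and "the series" means these few. Any claim that something is new, unique, unknown or untested is made for them only; others in the source may bear on it.

For the measured compounds named here, the three compounds measured so far share one core and were each tested in an ADME assay on BJ cells (Homo sapiens), read by MTT assay, with a stated time of 72 h; on this read-out higher numbers stand for weaker inhibition and lower numbers for stronger inhibition. Compound 1 `Nc1nc(N)c2c(-c3ccsc3)cn([C@@H]3O[C@H](CO)[C@@H](O)[C@H]3O)c2n1` is reported in this assay only as a limit, > 100000 nM, and not as a number. Compound 2 `COc1nc(N)nc2c1c(-c1ccccc1)cn2[C@@H]1O[C@H](CO)[C@@H](O)[C@H]1O` likewise reaches only the limit of this assay, > 100000 nM. Compound 3 `Cc1nc(N)c2c(-c3ccccc3)cn([C@@H]3O[C@H](CO)[C@@H](O)[C@H]3O)c2n1` gives > 100000 nM in this assay, which again is a limit rather than a measured number. Where compound 3 stands can therefore be said only as far as the limit allows: all three values sit at the limit of > 100000 nM in this assay, at which 3 of the 3 values shown sit, so no ordering among compound 1, compound 2 and compound 3 can be drawn, and no step between measured compounds can be computed.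

Compound 4 `Nc1nc(N)c2c(-c3ccccc3)cn([C@@H]3O[C@H](CO)[C@@H](O)[C@H]3O)c2n1` has not yet been measured in this assay. It differs from compound 3 by amino in place of methyl on an aromatic carbon. Going by the values given here, with every value shown sitting at the limit of > 100000 nM in this assay, at which 3 of the 3 values shown sit, there is no measured step on which to scale this change. The step from compound 3 to compound 4 is expected to be a number no higher from compound 3 to compound 4 (the limit leaves the size open), that is, none beyond the usual scatter. Compound 4 is accordingly estimated at 100000 nM, with a range from 40000 nM to 300000 nM, and is most likely to be reported again only as a limit.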

Compound 4, half-maximal inhibitory concentration: > 100000 nM
Compound 4: a limit, no number; the forecaster's own chance of this, stated with the estimate: 85%; the middle value lies on the limit itself.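

For the compounds shown here, compound 4 is reported in this assay only as a limit, > 100000 nM, so no step from compound 1, compound 2 or compound 3 to compound 4 can be read: the limit of > 100000 nM in this assay, at which 4 of the 4 values shown sit. The compounds shown leave open whether amino, methyl or methoxy on that aromatic carbon, or phenyl in place of thiophen-3-yl, makes any difference in this assay.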